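Bromo in place of hydrogen on the phenol ring

The compounds below may be only part of what the source reports. "The series", "measured", "known", "first", "only" and "open" are said of these compounds alone.

Measured compounds:
compound 1 `Cc1ccc(C(=O)CC(=O)c2cc3ccccc3s2)c(O)c1` — 23.1 ug/mL
compound 2 `O=C(CC(=O)c1ccccc1O)c1cc2ccccc2s1` — 7.86 ug/mL
compound 3 `O=C(CC(=O)c1cc(Cl)cc(Cl)c1O)c1cc2ccccc2s1` — > 100 ug/mL

In an ADME assay on HeLa cells (Homo sapiens) for inhibition, read by MTT assay, with a stated time of 72 h (on this read-out lower numbers stand for stronger inhibition of growth and higher numbers for weaker inhibition of growth), compound 2 gives 7.86 ug/mL, the lowest of the two numbers shown. Among the compounds with values here, its nearest neighbour is compound 1, and the one step that differs in a single place, a 2.9-fold lower number from compound 1 to compound 2 (0.47 log units; beyond the scatter), runs from compound 1 to compound 2, hydrogen in place of methyl on an aromatic carbon. Compound 3 carries two chloro groups on the same ring, and in this assay compound 3 reaches only a limit, > 100 ug/mL (the limit of > 100 ug/mL in this assay, at which 1 of the 3 values shown sits); it is not a number.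

Compound 4 `O=C(CC(=O)c1cc(Br)ccc1O)c1cc2ccccc2s1` is not yet measured. It differs from compound 2 in this way: bromo in place of hydrogen on an aromatic carbon. Within the data shown here, no measured step puts a single halogen on this ring, so the step from compound 1 to compound 2 and the limit of compound 3 are the only bearings. Adding a substituent to the bare ring of compound 2 is expected to raise the number, and compound 4 is expected to give 20 ug/mL (range 8 ug/mL to 60 ug/mL), a step of a 2.5-fold higher number from compound 2 to compound 4 (0.41 log units; beyond the scatter), with some chance that only a limit is reported.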

Compound 4, concentration for 50% growth inhibition: 6.75 ug/mL
Compound 4: the middle estimate sits 3.0-fold (0.47 log units) above what was measured; measured number below the stated range.
By their numbers in this assay, from the lowest: compounds 4 and 2 (each within the scatter of the next); then compound 1. At a limit, above all of these: compound 3.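

In this assay, bromo on this aromatic carbon, para to a hydroxy group, leaves the number where it was: a 1.2-fold lower number from compound 2 to compound 4 (0.07 log units; within the scatter). Within the data shown here, this shows that a single halogen can sit at this position of the phenol ring without moving the result beyond the scatter, which the earlier compounds could not show, since none of them carried one halogen alone on this ring. Compound 3, with two chloro groups on that ring, remains a separate case, and its value is a limit and not a number: the limit of > 100 ug/mL in this assay, at which 1 of the 4 values shown sits.

The compounds shown leave open whether a single chloro at this carbon would behave as bromo does, and which of the two chloro groups of compound 3 goes with that limit. They also leave open how an amine or a carboxylic acid would fare at this position.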